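This account rests on a few compounds, and the source may have more. Where it says the series, first, only, none or still open, it means among the compounds named here.

Compound 3 `NC(=O)c1cccc(NC(=O)c2ccc(-c3ccccc3)cc2)c1` and compound 2 `COC(=O)c1cccc(NC(=O)c2ccc(-c3ccccc3)cc2)c1` share one core and differ by methoxy in place of amino on a carbonyl carbon. In a physicochemical assay for solubility (on this read-out higher numbers stand for higher solubility and lower numbers for lower solubility), compound 3 gives 25 ug/mL. For compound 2 this assay reports only a limit, < 5 ug/mL. The step is thus an at least 5.0-fold lower number from compound 3 to compound 2 (0.69 log units; beyond the scatter), its size bounded by the limit of < 5 ug/mL in this assay, at which 1 of the 3 values shown sits. Compound 1 `NC(=O)c1cccc(NC(=O)c2ccc3ccccc3n2)c1` carries the carbamoyl on another core; the difference between the two cores is not broken down here. In this assay compound 1 gives 10 ug/mL, the lower of the two numbers. Compound 4 `COC(=O)c1cccc(NC(=O)c2ccc3ccccc3n2)c1` is unmeasured and differs from compound 1 by methoxy in place of amino on a carbonyl carbon, the same change as from compound 3 to compound 2. The step from compound 1 to compound 4 is expected to be a 5.0-fold lower number from compound 1 to compound 4 (0.70 log units; beyond the scatter), comparable to the earlier one, because compound 3 already fell to a limit in an at least 5.0-fold lower number from compound 3 to compound 2 (0.69 log units; beyond the scatter). Compound 4 is estimated at 2 ug/mL, most likely again reported only as a limit in this assay.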

Compound 4, solubility: 25 ug/mL
Compound 4: the middle estimate sits 13-fold (1.10 log units) below what was measured; the measured number lies above the stated range.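

On the core of compound 1, the change from carbamoyl to methoxycarbonyl gives a 2.5-fold higher number from compound 1 to compound 4 (0.40 log units; beyond the scatter) in this assay whereas on the other core it gave an at least 5.0-fold lower number from compound 3 to compound 2 (0.69 log units; beyond the scatter) and so the direction of the step did not carry from one core to the other. This shows that the outcome differs between these two pairs, but it does not show what in the cores sets that difference, and two pairs give no rule for the series. The earlier step also has no exact size, because compound 2 stands at a limit: the limit of < 5 ug/mL in this assay, at which 1 of the 4 values shown sits.

The compounds shown leave open how a carboxylic acid or ethoxy would behave on this carbonyl carbon in either core. On these data alone, whether either direction holds on a further core also stays open.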